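This account rests on a few compounds, and the source may have more. Where it says the series, first, only, none or still open, it means among the compounds named here.

Measured so far in a functional assay on the whole organism (strain Wistar) for inhibition, with Rattus norvegicus as the target, read by paw edema, with stated times of 60 min and 1 h, at a dose of 100 mg/kg by the oral route; a higher number here means more inhibition at the dose given (going by the name of the read-out), a lower number less inhibition:

Compound 1 `COc1cc2c(cc1OC)C(CC(N)=O)CC2`: 18.8%
Compound 2 `COc1cc2c(cc1OC)C(CC(=O)N(C)C)CC2`: 25%
Compound 3 `COc1cc2c(cc1OC)C(CC(=O)NC(C)(C)C)CC2`: 31.3%

For the measured compounds named here, compound 3 holds the highest of the three numbers, although the step of a number 6.3 percentage points higher from compound 2 to compound 3 (within the scatter) lies within the usual scatter and only the step of a number 12.5 percentage points higher from compound 1 to compound 3 (beyond the scatter) goes beyond it. Compound 4 `COc1cc2c(cc1OC)C(CC(=O)NCc1ccccc1)CC2` differs from compound 3 in one place: benzyl in place of tert-butyl on an amide-type nitrogen. Both measured steps that touch the amide nitrogen, a number 12.5 percentage points higher from compound 1 to compound 3 (beyond the scatter) and a number 6.3 percentage points higher from compound 2 to compound 3 (within the scatter), were small and upward, and the larger substituent gave the higher number. Going by the values given here, no measured compound carries a benzyl group, so the expected step is modest. Compound 4 is expected to give 33%, with a range from 20% to 46%. The estimated step is a number 1.7 percentage points higher from compound 3 to compound 4 (within the scatter).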

Compound 4, a percentage reported as inhibition, in the whole organism at one dose (the size of the read-out at that dose, not a potency): 18.8%
Compound 4: the middle estimate sits 14.2 percentage points above what was measured, and the stated range ends above it.
By their numbers in this assay, from the lowest: compounds 1, 4, 2 and 3 (each within the scatter of the next, the first and the last beyond it).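

Benzyl has more heavy atoms than tert-butyl, yet this change on the amide-type nitrogen gives a number 12.5 percentage points lower from compound 3 to compound 4 (beyond the scatter) in this assay and breaks the earlier match between a bigger group and a higher number. The other two steps, a number 6.2 percentage points lower from compound 2 to compound 4 (within the scatter) and no change at the digits printed from compound 1 to compound 4 (within the scatter), leave compound 4 within the scatter of both simpler amides, so adding the aromatic ring brings no measurable gain over them. Nothing available explains the drop. Still open, from the compounds shown here alone, is how a phenethyl group, with a longer chain, or a cyclohexylmethyl group, with a saturated ring, would read on the same nitrogen. Going by these compounds, a carboxylic acid in place of the amide is equally open.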